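From fluoro to trifluoromethyl at the assay limit

A few compounds are considered here, and "the series" means these few. Any claim that something is new, unique, unknown or untested is made for them only; others in the source may bear on it.

In an ADME assay on HaCaT cells (Homo sapiens) for antiproliferative activity, read by MTT assay, with a stated time of 48 h (on this read-out higher numbers stand for weaker inhibition and lower numbers for stronger inhibition), compound 1 (`O=C(/C=C\Nc1ccc(F)cc1)c1cn(-c2ccccc2)nc1-c1ccc(F)cc1`) gives > 50000 nM as a limit of the assay. Compound 2 (`O=C(/C=C\Nc1ccc(F)cc1)c1cn(-c2ccccc2)nc1-c1ccc(Cl)cc1`) gives > 50000 nM and this too is only a limit, so it has no exact place on the scale. Compound 3 (`O=C(/C=C\Nc1ccc(C(F)(F)F)cc1)c1cn(-c2ccccc2)nc1-c1ccc(Cl)cc1`) carries trifluoromethyl in place of fluoro on an aromatic carbon, para to a large group (trifluoromethyl in place of fluoro on an aromatic carbon). Among the measured compounds shown here, the one measured step is a step that the two limits leave unreadable from compound 1 to compound 2 and has no size to lend, and the evidence amounts to the limit of > 50000 nM in this assay, at which 2 of the 2 values shown sit, alone. The expected move is a number no higher from compound 2 to compound 3 (the limit leaves the size open) in this assay and no step beyond the scatter is expected. Compound 3 is estimated at 50000 nM within an expected range of 25000 nM to 100000 nM and will probably be reported as a limit again.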

Compound 3, half-maximal inhibitory concentration: > 50000 nM
Compound 3: a limit, no number (the forecaster's own chance of this, stated with the estimate: 80%); the middle value sits exactly at the limit.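

In this assay compound 2 and compound 3 both stand only as limits, so no step can be read between them. The compounds shown leave open where on the scale any of them truly lies.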